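Bromo to methyl at a cytotoxicity limit

The compounds below may be only part of what the source reports. "The series", "measured", "known", "first", "only" and "open" are said of these compounds alone.

Compound 3 `COc1ccc([C@H]2CC(=O)N(c3cccc(NS(=O)(=O)c4ccccc4Br)c3)C2)cc1OC1CCCC1` gives > 10000 nM in a functional assay on HEK293 cells (Homo sapiens) for cytotoxicity (a lower number here means that less compound is tolerated, a higher number that more compound is tolerated), and this is a limit and not a number. Compound 1 `COc1ccc([C@H]2CC(=O)N(c3cccc(NS(=O)(=O)c4cccc(Cl)c4C)c3)C2)cc1OC1CCCC1` gives > 10000 nM in this assay, which is likewise a limit. Compound 2 `COc1ccc([C@H]2CC(=O)N(c3cccc(NS(=O)(=O)c4ccc(F)cc4)c3)C2)cc1OC1CCCC1` gives > 10000 nM, again a limit. Within the data shown here, compound 3 therefore has no readable value, and the series so far offers only (the limit of > 10000 nM in this assay, at which 3 of the 3 values shown sit).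

The next compound, compound 4 `COc1ccc([C@H]2CC(=O)N(c3cccc(NS(=O)(=O)c4ccccc4C)c3)C2)cc1OC1CCCC1`, replaces the 2-bromophenyl group with 2-methylphenyl on the sulfonyl sulfur. The difference is methyl in place of bromo on an aromatic carbon, ortho to a large group.

Three measured changes of the group on that sulfur bear on this one. They are a step that the two limits leave unreadable from compound 1 to compound 2, a step that the two limits leave unreadable from compound 1 to compound 3 and a step that the two limits leave unreadable from compound 2 to compound 3. Among the measured compounds shown here, none has a readable size, so they give no measured step to carry over. Even so, compound 1, compound 2 and compound 3 all stay at the same limit, and none of them goes against it. No step beyond the usual scatter is therefore expected, and no direction can be given. The expected step is a step that the limit leaves unreadable from compound 3 to compound 4.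

For compound 4 the estimated value is 15000 nM, with an expected range of 7000 nM to 40000 nM, and most likely only a limit will be reported.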

Compound 4, half-maximal cytotoxic concentration: > 10000 nM
Compound 4 gave a limit, no number; the forecaster's own chance of this, stated with the estimate: 90%; the middle value lies beyond the limit too.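

In this assay compound 4 gives > 10000 nM, which is a limit and not a number. Its steps from compound 1, compound 2 and compound 3 therefore cannot be read, and the series stands at one limit: the limit of > 10000 nM in this assay, at which 4 of the 4 values shown sit.

The compounds shown leave open how these four compounds compare with one another in this assay, and whether any group on the sulfonyl sulfur would give a readable value.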